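Removing one chlorine from a dichlorinated purine-type core

The source may hold more compounds than are shown below. What is called first, only, known or untested is meant among the compounds shown, and "the series" means these compounds.

Compound 2 `ClCc1ccc(Cn2cnc3nc(Cl)nc(Cl)c32)cc1` gives 79400 nM in a functional assay on NCI-H460 cells (Homo sapiens) for cytotoxicity, read by sulforhodamine B assay, with a stated time of 48 h; a higher number here means that more compound is tolerated, a lower number that less compound is tolerated; compound 1 `ClCc1ccc(Cn2cnc3c(Cl)ncnc32)cc1` gives 26900 nM.

Of these two numbers, compound 2 stands highest, with compound 1 the nearer and lower one. Compound 3 `ClCc1ccc(Cn2cnc3ncnc(Cl)c32)cc1` has not been measured; it differs from compound 2 by hydrogen in place of chloro on an aromatic carbon. For the measured compounds named here, with no step between measured compounds to lean on, the expectation rests on the two values alone: compound 1, which also carries a single chloro on its core, shows the lower number. A modest drop in the number from compound 2 to compound 3 is therefore expected, a 2.0-fold lower number from compound 2 to compound 3 (0.30 log units; within the scatter). Compound 3 is estimated at 40000 nM, within 15000 nM to 100000 nM.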

Compound 3, concentration lethal to 50% of the cells: 17400 nM
Compound 3: middle estimate off by 2.3-fold (0.36 log units), on the high side; the measured number falls inside the stated range.
By their numbers in this assay, from the lowest: compounds 3 and 1 (each within the scatter of the next); then compound 2.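

In this assay, the chloro between two ring nitrogen atoms can be exchanged for hydrogen with a clear result: there is a 4.6-fold lower number from compound 2 to compound 3 (0.66 log units; beyond the scatter) once it leaves. This chloro is therefore not required for cytotoxicity on these cells, and less of the compound is tolerated without it. Nothing available explains this change. As far as these compounds go, whether an amine or a methoxy group on this same carbon would lower the number further or raise it remains open, as does the effect of replacing the other chloro on this core.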